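Methoxy to ethoxy on compound 3

The compounds below may be only part of what the source reports. "The series", "measured", "known", "first", "only" and "open" are said of these compounds alone.

Measured in a functional assay on HepG2 cells (Homo sapiens) for cytotoxicity, with a stated time of 72 h; a higher number here means that more compound is needed for the effect, a lower number that less compound is needed:
Compound 1 (`COc1ccc(/C=C/[C@@](C)(/C=C/c2ccc(O)c(C=O)c2)CCC=C(C)C)cc1`) gives > 26000 nM as a limit
Compound 2 (`COc1ccc(/C=C/[C@@](C)(/C=C/c2ccc(O)c(/C=C/C(=O)c3ccccc3)c2)CCC=C(C)C)cc1`) gives > 52000 nM as a limit
Compound 3 (`COc1ccc(/C=C/[C@@](C)(/C=C/c2ccc(O)cc2)CCC=C(C)C)cc1`) gives > 52000 nM as a limit

None of the three compounds gives a number. Compound 3 stands at the limit of > 52000 nM in this assay, at which 2 of the 3 values shown sit, and so offers only a limit as a starting point. Compound 1 stands at the limit of > 26000 nM in this assay, at which 1 of the 3 values shown sits, instead.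

The change to compound 4 (`CCOc1ccc(/C=C/[C@@](C)(/C=C/c2ccc(O)cc2)CCC=C(C)C)cc1`) is methyl in place of hydrogen on a saturated chain carbon bound to an oxygen on an aromatic ring and it amounts to methoxy to ethoxy. Three measured steps are available, namely a step that the two limits leave unreadable from compound 1 to compound 2 and a step that the two limits leave unreadable from compound 1 to compound 3 and a step that the two limits leave unreadable from compound 2 to compound 3 and none of them gives a size. All three concern formyl, 2-benzoylethenyl or hydrogen on an aromatic carbon, and none touches the methoxy group. With no size to carry over, no step beyond the usual scatter is expected in this assay and compound 4 is expected to be reported as a limit too. The expected change is a step that the limit leaves unreadable from compound 3 to compound 4 and this is a weakly founded estimate. For compound 4 the estimated value is 60000 nM within an expected range of 25000 nM to 150000 nM on this reading.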

Compound 4, half-maximal effective concentration: > 52000 nM
Compound 4 gave a limit, no number (the forecaster's own chance of this, stated with the estimate: 80%); the middle value is on the limit's open side.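

In this assay, compound 3 and compound 4 are both reported only as limits, so no step can be read for the change from methoxy to ethoxy. The compounds shown leave open whether this change alters the half-maximal effective concentration at all, and how large any such step would be.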